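Amino in Place of Hydroxy on a Benzyl Group

This account rests on a few compounds, and the source may have more. Where it says the series, first, only, none or still open, it means among the compounds named here.

Of the compounds shown here, three with a shared core have been tested in a functional assay on Bel7402/5-FU cells (Homo sapiens) for antiproliferative activity, read by MTT assay, with a stated time of 72 h; a higher number here means a weaker inhibitor, a lower number a stronger inhibitor. Compound 1 `COc1cccc(CNCc2c(C(=O)O)n(Cc3ccc(C)cc3)c3cc(C)ccc23)c1` gives 7310 nM. Compound 3 `COc1cccc(CNCc2c(C(=O)O)n(Cc3ccccc3)c3cc(C)ccc23)c1` gives 12100 nM. The two are linked by a 1.7-fold higher number from compound 1 to compound 3 (0.22 log units; within the scatter), so the methyl on the aromatic carbon makes no difference beyond the scatter. Compound 2 `COc1cccc(CNCc2c(C(=O)O)n(Cc3ccc(O)cc3)c3cc(C(C)C)ccc23)c1` stands apart: in this assay compound 2 gives > 50000 nM, which is a limit of the assay and not a number. Compound 2 thus sits at the limit of > 50000 nM in this assay, at which 1 of the 3 values shown sits.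

Compound 4 `COc1cccc(CNCc2c(C(=O)O)n(Cc3ccc(N)cc3)c3cc(C(C)C)ccc23)c1` is the compound not yet measured. It differs from compound 2 only by amino in place of hydroxy on an aromatic carbon. For the measured compounds named here, no measured step bears on this change; the single measured step concerns a methyl and hydrogen, not a hydroxy or amino. Going by the values given here, because compound 2 gives > 50000 nM, the starting point is already at the edge of what this assay reads, and no step says how far the amino moves it. For compound 4 the estimate in this assay is 40000 nM, with a range from 12000 nM to 120000 nM. This amounts to an expected at least 1.2-fold lower number from compound 2 to compound 4 (0.09 log units; that floor lies within the scatter), a step that could not be told from the scatter. Should compound 4 give a number, it is expected to lie in the same weak region as compound 1 and compound 3.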

Compound 4, half-maximal inhibitory concentration: > 50000 nM
Compound 4 gave a limit, no number; the forecaster's own chance of this, stated with the estimate: 45%; middle value at least 1.2-fold (0.09 log units) away from the limit.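

In this assay compound 4, like compound 2, reads only as a limit of the assay and not a number, so the step between these two compounds cannot be read: the limit of > 50000 nM in this assay, at which 2 of the 4 values shown sit.

The compounds shown leave open whether amino in place of hydroxy on the benzyl group changes the result in this assay at all.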